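Taking the bromo off compound 3

This account rests on a few compounds, and the source may have more. Where it says the series, first, only, none or still open, it means among the compounds named here.

Going by the values given here, in a functional assay on OCI-Ly3 cells (Homo sapiens) for antiproliferative activity (a higher number here means that more compound is needed for the effect, a lower number that less compound is needed), compound 3 `Cc1c(NC(=O)Nc2cnc(-n3nccn3)c(Cl)c2)cnc2ccc(Br)cc12` gives 12900 nM, the only actual number in this small set. Compound 1 `Cc1ncncc1NC(=O)Nc1cnc(-n2nccn2)c(Cl)c1` reports only a limit of the assay, > 20000 nM. Compound 2 `Cc1cc(C)c(NC(=O)Nc2cnc(-n3nccn3)c(Cl)c2)cn1` also reports only a limit, > 20000 nM. Among the compounds with values here, the one measured step, a step that the two limits leave unreadable from compound 1 to compound 2, therefore has no readable size, and the set offers only the limit of > 20000 nM in this assay, at which 2 of the 3 values shown sit, as a reference.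

Compound 4 `Cc1c(NC(=O)Nc2cnc(-n3nccn3)c(Cl)c2)cnc2ccccc12` carries hydrogen in place of bromo on an aromatic carbon. Within the data shown here, no measured step tests this change, so any expectation is weak. With compound 3 at 12900 nM, a small loss is the likeliest outcome, and the expected 1.2-fold higher number from compound 3 to compound 4 (0.09 log units; within the scatter) may not exceed the scatter. Compound 4 is estimated at 16000 nM, within an expected range of 6000 nM to 30000 nM.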

Compound 4, half-maximal effective concentration: 7170 nM
The estimate for compound 4 lay 2.2-fold (0.35 log units) above the measured number; the range from low to high includes it.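

In this assay, going by these compounds alone, hydrogen in place of bromo on this aromatic carbon amounts to a 1.8-fold lower number from compound 3 to compound 4 (0.26 log units; within the scatter) and so gives the first readable step in the set. Compound 3 and compound 4 both give an actual number rather than a limit, which shows that the bromo is not needed for a readable number in this pair. Nothing measured here accounts for the size of this step.

The compounds shown leave open whether a larger or different group on this carbon, such as an amine, a methoxy group or a carboxylic acid, would shift the number beyond the scatter. They also leave open whether chloro or fluoro would behave as bromo does here.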